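The compounds below may be only part of what the source reports. "The series", "measured", "known", "first", "only" and "open" are said of these compounds alone.

Compound 1 `COc1cc(C)cc(-c2c(-c3ccnc(-c4ccc(C(C)=O)cc4)c3)cnn2CC#N)c1`, compound 2 `Cc1cc(O)cc(-c2nn(CC#N)cc2-c2ccnc(-c3ccc(Oc4ccccc4)cc3)c2)c1` and compound 3 `COc1cc(C)cc(-c2nn(CC#N)cc2-c2ccnc(-c3ccc(N(C)C)cc3)c2)c1` share one core and differ in two outer groups. In a functional assay on A498 cells (Homo sapiens) for inhibition, read by sulforhodamine B assay, with a stated time of 48 h (on this read-out lower numbers stand for higher toxicity in this test and higher numbers for lower toxicity in this test), compound 2 gives 44100 nM. For compound 1 this assay reports only a limit, > 100000 nM. For compound 3 this assay likewise reports only a limit, > 100000 nM. Compound 3 therefore sits at the limit of > 100000 nM in this assay, at which 2 of the 3 values shown sit, and its place among the measured compounds cannot be fixed more closely than that. Compound 4 `Cc1cc(O)cc(-c2nn(CC#N)cc2-c2ccnc(-c3ccc(N(C)C)cc3)c2)c1` has not yet been measured. It differs from compound 3 in one place: hydrogen in place of methyl on an oxygen on an aromatic ring. For the measured compounds named here, no measured pair shows this change alone, and the step it brings in this assay is open. Compound 2 carries the same hydroxy group and gives a readable number, 44100 nM, rather than a limit. A small expected step of an at least 1.2-fold lower number from compound 3 to compound 4 (0.09 log units; that floor lies within the scatter), likely still within the scatter, is taken from that. Compound 4 is estimated at 80000 nM in this assay, within a range from 30000 nM to 200000 nM, with a fair chance that only a limit is again reported.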

Compound 4, concentration lethal to 50% of the cells: > 100000 nM
Compound 4: only a limit was reported (the forecaster's own chance of this, stated with the estimate: 55%); middle value at least 1.2-fold (0.09 log units) away from the limit.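

In this assay compound 4 gives only a limit, > 100000 nM, and the series now gathers at that limit: the limit of > 100000 nM in this assay, at which 3 of the 4 values shown sit. Compound 3 and compound 4 both stand at limits, so the step from methoxy to hydroxy cannot be read. The hydroxy group alone does not bring a readable number, as dimethylamino in place of phenoxy on an aromatic carbon gives an at least 2.2-fold higher number from compound 2 to compound 4 (0.35 log units; beyond the scatter), a step beyond the usual scatter that ties the readable value in this pair to the phenoxy group.

From the compounds shown here alone, what the change from methoxy to hydroxy does when the phenoxy group is present stays open. So does whether a carboxylic acid or a longer ether chain in place of phenoxy would also give a readable number.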